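Bromo-to-methyl swap on two chromone-linked cores

The source may report more compounds than this note shows. Statements on the series, on what has been measured and on what is new or still open speak of the compounds shown alone.

Measured so far:
compound 1 `Cc1cccc2c1OCN(c1ccc3oc(-c4ccccc4)cc(=O)c3c1)C2` — 85.1%
compound 2 `O=c1cc(-c2ccccc2)oc2cc(N3COc4c(Br)cccc4C3)ccc12` — 19.5%
compound 3 `O=c1cc(-c2ccccc2)oc2ccc(N3COc4c(Br)cccc4C3)cc12` — 81.8%

All numbers come from a functional assay on MCF7 cells (Homo sapiens) for inhibition, read by MTT assay, with a stated time of 48 h, tested at 60 ug/mL; a higher number here means more inhibition of growth at the concentration tested, a lower number less inhibition of growth. Compound 2 has the lowest number of the three, and its gaps to compound 3 and to compound 1 lie beyond the scatter. Compounds 2 and 3 are built from the same atoms joined differently; the difference between the two cores is not broken down here.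

One change is seen twice. From compound 3 to compound 1 it is methyl in place of bromo on an aromatic carbon and gives a number 3.3 percentage points higher from compound 3 to compound 1 (within the scatter). The same change carries compound 2 to compound 4 `Cc1cccc2c1OCN(c1ccc3c(=O)cc(-c4ccccc4)oc3c1)C2`: methyl in place of bromo on an aromatic carbon.

For compound 4 a step like a number 3.5 percentage points higher from compound 2 to compound 4 (within the scatter) is expected in this assay, resting on the step from compound 3 to compound 1 and on compound 2 giving 19.5%. Compound 4 is therefore estimated at 23%, between 8% and 45%.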

Compound 4, percent growth inhibition at one concentration: 66.6%
Compound 4: the middle estimate sits 43.6 percentage points below what was measured; the whole stated range lies below it.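

In this assay the swap of bromo for methyl on an aromatic carbon does not carry over unchanged from one core to the other: the same change on two cores in this assay, a number 3.3 percentage points higher (within the scatter) from compound 3 to compound 1 and a number 47.1 percentage points higher (beyond the scatter) from compound 2 to compound 4, 43.8 percentage points apart, beyond the scatter of two such steps

The large step, a number 47.1 percentage points higher from compound 2 to compound 4 (beyond the scatter), therefore belongs to one core and cannot be read as a general gain for methyl over bromo. Two pairs do not show why the cores respond differently, nor what the change would give on any further core.

The compounds shown leave open whether other groups on this aromatic carbon, such as chloro, methoxy or an amine, would also depend on the core. They also leave open whether replacing the phenyl on the core would alter the gap between the two steps.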